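The compounds below may be only part of what the source reports. "The series", "measured", "known", "first", "only" and "open" are said of these compounds alone.

Compound 1 `CCOC(=O)/C(O)=C/C(=O)c1cn(Cc2ccc(F)c(F)c2)c2cccc(OC)c12` gives 125000 nM.
Compound 2 `CCOC(=O)/C(O)=C/C(=O)c1cn(Cc2cccc(F)c2)c2cccc(OC)c12` gives 63200 nM.
Compound 3 `CCOC(=O)/C(O)=C/C(=O)c1cn(Cc2ccc(F)cc2F)c2cccc(OC)c12` gives 65500 nM.

All three numbers come from an ADME assay on MT4 cells (Homo sapiens) for cytotoxicity, read by MTT assay; on this read-out lower numbers stand for higher toxicity in this test and higher numbers for lower toxicity in this test. Compound 3 sits close to its two neighbours: the nearest is compound 2, with a 1.0-fold higher number from compound 2 to compound 3 (0.02 log units; within the scatter), and the furthest is compound 1, with a 1.9-fold lower number from compound 1 to compound 3 (0.28 log units; within the scatter), so the three measured compounds are indistinguishable in this assay. Compound 1 and compound 2 are likewise separated only by a 2.0-fold lower number from compound 1 to compound 2 (0.30 log units; within the scatter).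

Compound 4 `CCOC(=O)/C(O)=C/C(=O)c1cn(Cc2cc(F)ccc2F)c2cccc(OC)c12` differs from compound 3 in one place: 2,5-difluorophenyl in place of 2,4-difluorophenyl on a saturated chain carbon bound to an aromatic nitrogen. In words, the two fluorine atoms on the benzyl group stay, but one of them moves to a different carbon of the ring.

The measured steps that bear on this are those where the fluorine pattern of the same benzyl ring was altered: a 1.9-fold lower number from compound 1 to compound 3 (0.28 log units; within the scatter) and a 1.0-fold higher number from compound 2 to compound 3 (0.02 log units; within the scatter). Neither went beyond the scatter, and the two patterns tested so far all land at the same level of cytotoxicity. The change to compound 4 is of the same kind, so no step beyond the scatter is expected in this assay, in either direction.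

Compound 4 is therefore estimated at 65000 nM, with a range from 30000 nM to 140000 nM, which means an expected step of a 1.0-fold lower number from compound 3 to compound 4 (0.00 log units; within the scatter).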

Compound 4, half-maximal cytotoxic concentration: 41200 nM
Beside the measured number, compound 4's estimate is 1.6-fold (0.20 log units) above it, within the range that was stated.
By their numbers in this assay, from the lowest: compounds 4, 2, 3 and 1 (each within the scatter of the next, the first and the last beyond it).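

Swapping 2,4-difluorobenzyl for 2,5-difluorobenzyl keeps the same atoms and changes only how they are joined, and in this assay this stays within the scatter (a 1.6-fold lower number from compound 3 to compound 4 (0.20 log units; within the scatter)), as does the comparison with the single-fluorine ring of compound 2 (a 1.5-fold lower number from compound 2 to compound 4 (0.19 log units; within the scatter)). Within the data shown here, the new information comes from the pair with the 3,4-difluorophenyl group, which gives the first step beyond the scatter in this small set, though a modest one (a 3.0-fold lower number from compound 1 to compound 4 (0.48 log units; beyond the scatter)), and the lower number stands for higher toxicity in this test. Fluorine placement on this ring can therefore separate two compounds of identical composition, but only this one pair shows it, as compound 2 and compound 3 each remain within the scatter of both compound 1 and compound 4. No measurement on hand accounts for this gap.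

The compounds shown carry only fluorine on this ring, so they leave open how a chloro or methyl group, or an amine, would behave at the same place. They also leave open whether a carboxylic acid in place of the ethyl ester would change the cytotoxicity read-out.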